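Replacing 3-nitrophenyl with 4-bromophenyl

The source may report more compounds than this note shows. Statements on the series, on what has been measured and on what is new or still open speak of the compounds shown alone.

Measured in a functional assay on PC-3 cells (Homo sapiens) for cytotoxicity, read by MTT assay, with a stated time of 72 h; on this read-out lower numbers stand for stronger inhibition and higher numbers for weaker inhibition
- compound 1 `CNC(=O)c1cc(Oc2ccc(C3=NNC(c4cc(OC)c(OC)c(OC)c4)C3)cc2)ccn1` gives 28300 nM
- compound 2 `CNC(=O)c1cc(Oc2ccc(C3=NNC(c4ccc(C#N)cc4)C3)cc2)ccn1` gives 9910 nM
- compound 3 `CNC(=O)c1cc(Oc2ccc(C3=NNC(c4cccc([N+](=O)[O-])c4)C3)cc2)ccn1` gives "not determined" (no result reported)

Compound 3 has no single number in this assay and so offers no starting value. Compound 4 `CNC(=O)c1cc(Oc2ccc(C3=NNC(c4ccc(Br)cc4)C3)cc2)ccn1` differs from it by one change 4-bromophenyl in place of 3-nitrophenyl on a saturated ring carbon with 4-bromophenyl in place of 3-nitrophenyl on a saturated ring carbon. Without a value for compound 3, no size or direction can be expected for this step. Going by the values given here, the only guides are compound 2 at 9910 nM and compound 1 at 28300 nM and a value in that general region is expected. For compound 4 the estimated value is 13000 nM with an expected range from 4000 nM to 40000 nM in this assay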

Compound 4, half-maximal inhibitory concentration: > 50000 nM
Compound 4 ended at the assay's limit; the forecaster's own chance of this, stated with the estimate: 10%; middle value at least 3.8-fold (0.58 log units) from the limit.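

Compound 4 sits at a limit of this assay and has no exact number: the limit of > 50000 nM in this assay, at which 1 of the 4 values shown sits. Even so, putting bromo in place of cyano on this aromatic ring gives an at least 5.0-fold higher number from compound 2 to compound 4 (0.70 log units; beyond the scatter), so one swap on the ring carried by the saturated ring carbon is enough to move the read-out beyond the usual scatter. The step from compound 3 cannot be read, since compound 3 has no reported result. Still open, going by these compounds, are the true value of compound 4 and whether an amine or a carboxylic acid in place of the bromo would give a lower number than compound 2.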